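Replacing pyridin-2-yl with 3-(trifluoromethyl)phenyl on a carbonyl carbon

The source may hold more compounds than are shown below. What is called first, only, known or untested is meant among the compounds shown, and "the series" means these compounds.

Compound 1 `Cc1ccc(S(=O)(=O)N[C@@H](CC(=O)NC(C)(C)C)C(=O)NCCNC(=O)c2ccc(F)cc2)cc1` and compound 2 `Cc1ccc(S(=O)(=O)N[C@@H](CC(=O)NC(C)(C)C)C(=O)NCCNC(=O)c2ccccn2)cc1` share one core and differ only in the group on a carbonyl carbon. In an ADME assay on HepG2 cells (Homo sapiens) for cytotoxicity (a higher number here means that more compound is needed for the effect, a lower number that less compound is needed), compound 1 gives > 11000 nM, which is a limit and not a number. In this assay compound 2 gives > 11000 nM, again a limit. Compound 2 thus stands at the limit of > 11000 nM in this assay, at which 2 of the 2 values shown sit.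

The next compound, compound 3 `Cc1ccc(S(=O)(=O)N[C@@H](CC(=O)NC(C)(C)C)C(=O)NCCNC(=O)c2cccc(C(F)(F)F)c2)cc1`, carries 3-(trifluoromethyl)phenyl in place of pyridin-2-yl on a carbonyl carbon. Among the compounds with values here, one measured step bears on this change, a step that the two limits leave unreadable from compound 1 to compound 2, which also exchanged the group on that carbonyl carbon. Its size cannot be read, so it offers no size to carry over, and no direction can be drawn from it. With nothing pointing either way, no shift beyond the scatter is expected in this assay. The estimated step is a step that the limit leaves unreadable from compound 2 to compound 3, with no firm direction. Compound 3 is expected at about 14000 nM, with an estimated range from 6000 nM to 30000 nM, and the assay may well report only a limit again.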

Compound 3, half-maximal effective concentration: > 11000 nM
Compound 3: no number, only a limit; the forecaster's own chance of this, stated with the estimate: 80%; the middle value lies beyond the limit too.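

In this assay compound 3 gives > 11000 nM, a limit and not a number. The steps from compound 1 and from compound 2 to compound 3 cannot be read, and all three compounds share one limit: the limit of > 11000 nM in this assay, at which 3 of the 3 values shown sit. The compounds shown leave open whether the group on the carbonyl carbon alters the value in this assay at all.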